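The source may hold more compounds than are shown below. What is called first, only, known or untested is meant among the compounds shown, and "the series" means these compounds.

Measured compounds:
- compound 1, `Cc1nc(-c2ccc(C(F)(F)F)cc2)sc1CNc1ccc(CCC(=O)O)cc1`, in a functional assay on CHO cells for agonist activity at Free fatty acid receptor 1 (Homo sapiens), read by a luciferase reporter (on this read-out higher numbers stand for larger maximal responses and lower numbers for smaller maximal responses), gives 108%
- compound 2, `O=C(O)c1ccc(NCc2cccc(Oc3ccccc3)c2)cc1`, in this assay gives 86%
- compound 3, `O=C(O)CCCc1ccc(NCc2cccc(Oc3ccccc3)c2)cc1`, in this assay gives 59%

Compound 3 stands lowest of the three numbers; its nearest neighbour is compound 2, and compound 1 lies furthest from it, both beyond the scatter. Compound 4, `O=C(O)/C=C/c1ccc(NCc2cccc(Oc3ccccc3)c2)cc1`, has not yet been measured. It differs from compound 3 in one place: 2-carboxyethenyl in place of 3-carboxypropyl on an aromatic carbon. Going by the values given here, of the measured steps, only the one from compound 2 to compound 3 bears on this change, since it also alters the acid-bearing side chain on the shared core; that step was a number 27 percentage points lower from compound 2 to compound 3 (beyond the scatter). The carboxy of compound 2 and the 3-carboxypropyl of compound 3 bracket the 2-carboxyethenyl of compound 4 in chain length, so an upward step from compound 3 is expected, though smaller than the one just named. The expected step is a number 16 percentage points higher from compound 3 to compound 4 (beyond the scatter). Compound 4 is therefore estimated at 75%, with a range from 55% to 95%.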

Compound 4, largest response reached (reported as percent of maximum), in percent of the reference or control that the assay uses: 76%
For compound 4 the middle estimate is 1 percentage points below the measured one; the range from low to high includes it.
By their numbers in this assay, from the lowest: compound 3; then compounds 4 and 2 (each within the scatter of the next); then compound 1.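

In this assay, the acid-bearing side chain, para to a large group, proves sensitive to more than its presence alone: 2-carboxyethenyl in place of 3-carboxypropyl gives a number 17 percentage points higher from compound 3 to compound 4 (beyond the scatter), with one heavy atom fewer and one more double bond outside the aromatic rings. Set against carboxy, the same group gives a number 10 percentage points lower from compound 2 to compound 4 (within the scatter), so compound 4 does not separate from compound 2, whereas the 3-carboxypropyl group of compound 3 does. No measurement shown here accounts for this difference.

The compounds shown leave open whether the gain follows from the double bond or from the shorter chain, a question that a saturated 2-carboxyethyl group on the shared core would address. Also open, going by these compounds, is how a tetrazole or a primary amide in place of the carboxylic acid would fare at this position.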